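From 3-fluorobenzyl to 3-methylbenzyl: one open step

The compounds below may be only part of what the source reports. "The series", "measured", "known", "first", "only" and "open" are said of these compounds alone.

In a functional assay on cells (Hepatocyte, Rattus norvegicus) for inhibition, read by scintillation counting, with a stated time of 4 h (on this read-out higher numbers stand for weaker inhibition and lower numbers for stronger inhibition), compound 1 (`COc1ccc(CNC(=O)c2nc(-c3ccc(F)cc3)n(CC[C@@H](O)C[C@@H](O)CC(=O)O)c2C2CC2)cc1F`) gives 0.2 nM and compound 2 (`O=C(O)C[C@H](O)C[C@H](O)CCn1c(-c2ccc(F)cc2)nc(C(=O)NCc2cccc(F)c2)c1C1CC1`) gives 0.1 nM on the same read-out. Among the measured compounds shown here, compound 2 therefore stands level with compound 1 within the scatter, and the only measured step is a 2.0-fold lower number from compound 1 to compound 2 (0.30 log units; within the scatter) (hydrogen in place of methoxy on an aromatic carbon). Compound 3 (`Cc1cccc(CNC(=O)c2nc(-c3ccc(F)cc3)n(CC[C@@H](O)C[C@@H](O)CC(=O)O)c2C2CC2)c1`) has not yet been measured and differs from compound 2 in one place: methyl in place of fluoro on an aromatic carbon (methyl in place of fluoro on an aromatic carbon, meta to a large group). For the measured compounds named here, compound 1 and compound 2 both keep the fluoro, and no measured pair replaces it. Going by the values given here, the single step of a 2.0-fold lower number from compound 1 to compound 2 (0.30 log units; within the scatter) is thus only a loose guide, showing one change on that ring that stayed within the scatter. As far as these compounds go, no step beyond the scatter is therefore expected in this assay, and the direction remains open, with a slight lean towards a higher number. The step expected here is a 1.5-fold higher number from compound 2 to compound 3 (0.18 log units; within the scatter) in this estimate. For compound 3 the estimated value is 0.15 nM with an expected range from 0.05 nM to 0.5 nM on this read-out.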

Compound 3, half-maximal inhibitory concentration: 0.3 nM
For compound 3 the middle estimate is 2.0-fold (0.30 log units) below the measured one; the range from low to high includes it.
By their numbers in this assay, from the lowest: compounds 2, 1 and 3 (each within the scatter of the next, the first and the last beyond it).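

In this assay, putting methyl in place of fluoro on this aromatic carbon, the change from 3-fluorobenzyl to 3-methylbenzyl, gives a 3.0-fold higher number from compound 2 to compound 3 (0.48 log units; beyond the scatter). Among the compounds shown here, this is the first step to lie beyond the scatter, and it shows that the read-out responds, if only modestly, to the exchange of this single heavy atom on the ring. The wider change, 3-methylphenyl for 3-fluoro-4-methoxyphenyl, gives only a 1.5-fold higher number from compound 1 to compound 3 (0.18 log units; within the scatter), so that pair remains level, and nothing available accounts for either step.

What the compounds shown leave open is how other groups on this same aromatic carbon would compare with fluoro and methyl, for example chloro, trifluoromethyl, nitrile or an amine. With a single exchange read here, they also cannot tell whether the step seen with fluoro and methyl would hold on the core of compound 1 with another group in place of the 3-fluorobenzyl, or whether it belongs to this pair alone.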